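Arylidene hydrazide series: dihydroxyphenyl in place of methoxyphenyl

The compounds below may be only part of what the source reports. "The series", "measured", "known", "first", "only" and "open" are said of these compounds alone.

Measured compounds in a functional assay on HepG2 cells (Homo sapiens) for cytotoxicity, read by MTT assay, with a stated time of 48 h; on this read-out higher numbers stand for weaker inhibition and lower numbers for stronger inhibition:
compound 1 `O=C(CSc1nnc(-c2ccncc2)o1)N/N=C/c1ccc([N+](=O)[O-])cc1` – 17900 nM
compound 2 `COc1cccc(/C=N/NC(=O)CSc2nnc(-c3ccncc3)o2)c1` – 9170 nM

Among the measured compounds shown here, compound 2 holds the lowest of the two numbers so far, with compound 1 as its only neighbour at a 2.0-fold lower number from compound 1 to compound 2 (0.29 log units; within the scatter). The next compound, compound 3 `O=C(CSc1nnc(-c2ccncc2)o1)N/N=C/c1ccc(O)c(O)c1`, differs from compound 2 in one place: 3,4-dihydroxyphenyl in place of 3-methoxyphenyl on a carbon with a double bond to nitrogen.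

For the measured compounds named here, no measured step bears directly on this change. Going by the values given here, the only step in hand, a 2.0-fold lower number from compound 1 to compound 2 (0.29 log units; within the scatter), exchanged one aromatic substituent for another on the same carbon and did not leave the scatter; it shows that the ring attached to the carbon with a double bond to nitrogen can be varied without a clear shift in this assay. A step no larger than the scatter is therefore expected in either direction, a 1.0-fold lower number from compound 2 to compound 3 (0.01 log units; within the scatter). Compound 3 is estimated at 9000 nM, with a range of 3000 nM to 30000 nM.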

Compound 3, half-maximal inhibitory concentration: 760 nM
Compound 3: the middle estimate sits 12-fold (1.07 log units) above what was measured, and the stated range ends above it.
By their numbers in this assay, from the lowest: compound 3; then compounds 2 and 1 (each within the scatter of the next).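

In this assay the ring on the carbon with a double bond to nitrogen is not as indifferent as the earlier pair suggested: the exchange in a 2.0-fold lower number from compound 1 to compound 2 (0.29 log units; within the scatter) stayed within the scatter, but 3,4-dihydroxyphenyl gives a 12-fold lower number from compound 2 to compound 3 (1.08 log units; beyond the scatter) and also a 24-fold lower number from compound 1 to compound 3 (1.37 log units; beyond the scatter) and both steps lie beyond it. Among the compounds shown here, compound 3 is thus the most potent of the three, and it is also the only one whose ring carries hydrogen-bond donors, 2 against 0 for the 3-methoxyphenyl it replaces. Nothing available accounts for this step.

Still open, on these data alone, is whether both hydroxyl groups are needed, which 4-hydroxyphenyl or 3-hydroxyphenyl at this position would test. Also open, as far as these compounds go, is whether 3,4-dimethoxyphenyl, with the same placement but no hydroxyl hydrogens, would keep the low number.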